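From chloro to nitro on a shared core

A few compounds are considered here, and "the series" means these few. Any claim that something is new, unique, unknown or untested is made for them only; others in the source may bear on it.

- compound 1 (`Brc1ccc(C(c2c[nH]c3ccc(Br)cc23)c2c[nH]c3ccc(Br)cc23)cc1`) gives 3200 nM
- compound 2 (`N#Cc1ccc2[nH]cc(C(c3ccc(Cl)cc3)c3c[nH]c4ccc(C#N)cc34)c2c1`) gives 23600 nM

In a functional assay on MCF7 cells (Homo sapiens) for inhibition, read by MTT assay, with a stated time of 48 h (a higher number here means a weaker inhibitor, a lower number a stronger inhibitor), compound 2 holds the higher of the two numbers, which makes it the weaker inhibitor, and its gap to compound 1 lies beyond the usual scatter. Compound 3 (`N#Cc1ccc2[nH]cc(C(c3ccc([N+](=O)[O-])cc3)c3c[nH]c4ccc(C#N)cc34)c2c1`) keeps the core of compound 2 and changes one place: nitro in place of chloro on an aromatic carbon puts nitro in place of chloro on an aromatic carbon. Within the data shown here, no measured pair isolates a single change, so the guidance is thin. The expected 1.3-fold lower number from compound 2 to compound 3 (0.12 log units; within the scatter) is small, with no firm direction, and probably stays within the scatter. For compound 3 the estimated value is 18000 nM with an expected range from 6000 nM to 50000 nM around it.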

Compound 3, half-maximal inhibitory concentration: 23600 nM
Estimate against measurement, compound 3: 1.3-fold (0.12 log units) below; measured number inside the range.
By their numbers in this assay, from the lowest: compound 1; then compounds 2 and 3 (each within the scatter of the next).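

In this assay, among these compounds, nitro in place of chloro on an aromatic carbon gives no change at the digits printed from compound 2 to compound 3 (within the scatter), the first comparison here that isolates a single change. At this place, para to a large group, 4-chlorophenyl and 4-nitrophenyl therefore cannot be told apart in this measurement, even though nitro brings more heavy atoms and two hydrogen-bond acceptors. Nothing available explains this result. Still open, on these data alone, is whether an amine or a carboxylic acid at this place would shift the number, and whether the same swap would read alike on the core of compound 1.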